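A few compounds are considered here, and "the series" means these few. Any claim that something is new, unique, unknown or untested is made for them only; others in the source may bear on it.

Measured compounds:
compound 1, `COc1cc(C)c(NCCNC(=O)[C@H](CC(C)C)NC(=O)c2cccc(C)c2)c(C)c1`, 132 nM
compound 2, `Cc1cccc(C(=O)N[C@@H](CC(C)C)C(=O)NCCNc2ccc(Cl)cc2)c1`, 458 nM
compound 3, `Cc1cccc(C(=O)N[C@@H](CC(C)C)C(=O)NCCNc2ccc(F)cc2)c1`, 563 nM

All three were tested in an assay on isolated protein for inhibition of cathepsin S (Homo sapiens); on this read-out lower numbers stand for stronger inhibition and higher numbers for weaker inhibition. Compound 3 gives the highest number of the three, but its gap to compound 2 is small, shown as a 1.2-fold higher number from compound 2 to compound 3 (0.09 log units; within the scatter), which is within the scatter. Its gap to compound 1 is real: a 4.3-fold higher number from compound 1 to compound 3 (0.63 log units; beyond the scatter). Compound 4, `Cc1cccc(C(=O)N[C@@H](CC(C)C)C(=O)NCCN2CCc3cc(Cl)ccc32)c1`, differs from compound 3 in one place: 5-chloro-2,3-dihydro-1H-indol-1-yl in place of (4-fluorophenyl)amino on a saturated chain carbon, two bonds along the chain from an amide-type nitrogen. Going by the values given here, no measured step removes the hydrogen-bond donor on the amine nitrogen or closes it into a ring, so the closest guides are the swaps of the aryl group on that nitrogen, a 3.5-fold higher number from compound 1 to compound 2 (0.54 log units; beyond the scatter) and a 4.3-fold higher number from compound 1 to compound 3 (0.63 log units; beyond the scatter), both modest, and the halogen swap a 1.2-fold higher number from compound 2 to compound 3 (0.09 log units; within the scatter), within the scatter. A modest step in this assay is therefore expected for compound 4, with the direction uncertain; the estimate for compound 4 is 400 nM, in the range 100 nM to 1600 nM, meaning an expected step of a 1.4-fold lower number from compound 3 to compound 4 (0.15 log units; within the scatter).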

Compound 4, inhibition constant: 196 nM
Compound 4: middle estimate off by 2.0-fold (0.31 log units), on the high side; the range from low to high includes it.
By their numbers in this assay, from the lowest: compounds 1 and 4 (each within the scatter of the next); then compounds 2 and 3 (each within the scatter of the next).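

Closing the amine nitrogen into the 5-chloro-2,3-dihydro-1H-indol-1-yl ring removes its hydrogen-bond donor, yet inhibition in this assay does not suffer: replacing (4-fluorophenyl)amino gives a 2.9-fold lower number from compound 3 to compound 4 (0.46 log units; beyond the scatter), and replacing (4-chlorophenyl)amino gives a 2.3-fold lower number from compound 2 to compound 4 (0.37 log units; beyond the scatter). The earlier compounds shown here all carry that donor, so only now is it clear that this position does not need one for inhibition, and the second step shows that the improvement also appears when both groups carry a chlorine. No measurement here gives a cause for the change.

From the compounds shown here alone, the loss of the donor and the gain of the ring come together in this change, so their separate contributions remain open. A methyl group on the amine nitrogen, with the ring left open, would pull the two apart.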